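A few compounds are considered here, and "the series" means these few. Any claim that something is new, unique, unknown or untested is made for them only; others in the source may bear on it.

Compound 1 `O=C(CN1CCN(C(=O)c2ccc(Br)cc2)CC1)N1CCN(CCCc2c[nH]c3ccccc23)CC1` – 59300 nM
Compound 2 `O=C(CN1CCN(C(=O)c2cccc(Br)c2)CC1)N1CCN(CCCc2c[nH]c3ccccc23)CC1` – 80500 nM

Among the compounds with values here, in an ADME assay on SH-SY5Y cells (Homo sapiens) for cytotoxicity, read by MTT assay, with a stated time of 72 h (on this read-out higher numbers stand for weaker inhibition and lower numbers for stronger inhibition), compound 1 gives 59300 nM and is one of only two compounds with a number. Within the data shown here, its sole neighbour lies within the scatter, at a 1.4-fold higher number from compound 1 to compound 2 (0.13 log units; within the scatter) with 3-bromophenyl in place of 4-bromophenyl on a carbonyl carbon. Compound 3 `O=C(CN1CCN(C(=O)c2ccc(Br)cc2)CC1)N1CCN(CCCc2c[nH]c3ccc(F)cc23)CC1` keeps the 4-bromophenyl group of compound 1 and changes the other end of the molecule: fluoro in place of hydrogen on an aromatic carbon turns 1H-indol-3-yl into 5-fluoro-1H-indol-3-yl. Among the measured compounds shown here, no measured step touches that group, so the bromine step offers only a rough sense of how little these numbers have moved. No shift beyond the scatter is therefore expected in this assay in either direction, and the estimated step is a 1.1-fold lower number from compound 1 to compound 3 (0.03 log units; within the scatter) on this basis. For compound 3 the estimate is 55000 nM with an expected range from 25000 nM to 120000 nM as its span.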

Compound 3, half-maximal inhibitory concentration: 47400 nM
Estimate against measurement, compound 3: 1.2-fold (0.06 log units) above; low and high end bracket the measured number.
By their numbers in this assay, from the lowest: compounds 3, 1 and 2 (each within the scatter of the next).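

In this assay the step at the 1H-indol-3-yl end of the molecule, with 5-fluoro-1H-indol-3-yl taking its place, reads a 1.3-fold lower number from compound 1 to compound 3 (0.10 log units; within the scatter), so fluoro on this aromatic carbon leaves compound 3 inseparable from compound 1. The earlier pair spoke only for the bromophenyl end, and this result extends the same picture of numbers lying within the scatter to the opposite end of the molecule, though for this one position and this one substituent only. Nothing measured here bears on the reason for this result.

The compounds shown leave open whether methoxy or trifluoromethyl on the same aromatic carbon would also stay within the scatter of compound 1. They also leave open whether a longer chain carrying the 1H-indol-3-yl group would move the number beyond the scatter.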